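The source may hold more compounds than are shown below. What is called first, only, known or untested is meant among the compounds shown, and "the series" means these compounds.

In a functional assay on HCC827 cells (Homo sapiens) for inhibition, read by MTT assay, with a stated time of 48 h, tested at 10 uM (a lower number here means less inhibition, a higher number more inhibition at the concentration tested (going by the name of the read-out)), compound 1 `COc1cc(NC(=O)Nc2cc(Nc3cccc(C(C)(C)C)c3)ncn2)cc(OC)c1` gives 48.7%, the second highest of the three numbers measured. Compound 2 `COc1cc(NC(=O)Nc2cc(Nc3ccc(OC)c(C)c3)ncn2)cc(OC)c1` gives 48.3%, and compound 3 `COc1cc(NC(=O)Nc2cc(Nc3cc(C)cc(F)c3)ncn2)cc(OC)c1` gives 62.1%. The step of a number 0.4 percentage points lower from compound 1 to compound 2 (within the scatter) stays within the scatter, while a number 13.4 percentage points higher from compound 1 to compound 3 (beyond the scatter) and a number 13.8 percentage points higher from compound 2 to compound 3 (beyond the scatter) are modest steps beyond it. All three measured changes sit on the nitrogen on the aromatic ring; the group on the amide-type nitrogen is the same in every measured compound. Compound 4 `CC(C)(C)c1cccc(Nc2cc(NC(=O)Nc3c(Cl)cccc3Cl)ncn2)c1` changes that group instead: 2,6-dichlorophenyl in place of 3,5-dimethoxyphenyl on an amide-type nitrogen. For the measured compounds named here, no measured step touches this position, so neither size nor direction can be read from the series; the expected step of a number 2.7 percentage points lower from compound 1 to compound 4 (within the scatter) is therefore set near zero with a wide range. Compound 4 is expected to give 46%, between 20% and 72%.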

Compound 4, a percentage reported as inhibition, at one concentration (the size of the read-out at that concentration, not a potency): 37.3%
Compound 4: the middle estimate sits 8.7 percentage points above what was measured, within the range that was stated.
By their numbers in this assay, from the lowest: compound 4; then compounds 2 and 1 (each within the scatter of the next); then compound 3.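

The group on the amide-type nitrogen does affect the number in this assay: 2,6-dichlorophenyl in place of 3,5-dimethoxyphenyl gives a number 11.4 percentage points lower from compound 1 to compound 4 (beyond the scatter), a modest step that places compound 4 lowest of the four. This single step cannot separate the loss of the methoxy groups from the arrival of the chlorine atoms. Nothing available explains the fall.

Still open, as far as these compounds go, is whether an unsubstituted phenyl or an aliphatic amine at this position would raise or lower the number. Also open, from the compounds shown here alone, is whether the step holds when 3-fluoro-5-methylphenyl replaces 3-(tert-butyl)phenyl.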